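Ethyl to methyl on the piperazine of compound 1

The compounds below may be only part of what the source reports. "The series", "measured", "known", "first", "only" and "open" are said of these compounds alone.

Measured compounds:
compound 1 `CCN1CCN(c2c(S(=O)(=O)c3ccccc3)cnc3ccccc23)CC1` — 1.7%
compound 2 `COc1cccc(S(=O)(=O)c2cnc3ccc(F)cc3c2N2CCC(C)CC2)c1` — 90%

In an assay on isolated protein for displacement of a labelled ligand from metabotropic glutamate receptor 5 (Homo sapiens), with a stated time of 60 min, tested at 1 uM (on this read-out higher numbers stand for more inhibition at the one concentration tested (going by the name of the read-out) and lower numbers for less inhibition), compound 1 gives 1.7%, the lowest of the two numbers. Within the data shown here, compound 2 gives 90%, a gap well beyond the scatter, but the two compounds differ in several places and no single step links them. Compound 3 `CN1CCN(c2c(S(=O)(=O)c3ccccc3)cnc3ccccc23)CC1` differs from compound 1 only by hydrogen in place of methyl on a saturated chain carbon bound to an amine nitrogen in a ring. Among the measured compounds shown here, no measured pair isolates this change, so a step near zero, within the scatter, is expected: a number 1.3 percentage points higher from compound 1 to compound 3 (within the scatter). Compound 3 is estimated at 3%, between -8% and 15%.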

Compound 3, a percentage reported as inhibition, at one concentration (the size of the read-out at that concentration, not a potency): 7.7%
Compound 3: the middle estimate sits 4.7 percentage points below what was measured, and the stated range covers the measured number.
By their numbers in this assay, from the lowest: compounds 1 and 3 (each within the scatter of the next); then compound 2.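

In this assay, among these compounds, going from 4-ethylpiperazin-1-yl to 4-methylpiperazin-1-yl gives a number 6 percentage points higher from compound 1 to compound 3 (within the scatter) and is the first measured step at this position. On the shared core, ethyl and methyl on this piperazine nitrogen cannot be told apart, so this change alone does not move the read-out. No measurement available here bears on the reason for this step.

Open, from the compounds shown here alone, is whether a longer chain, such as n-butyl, or a benzyl group at this position would separate from these two. Also open, going by these compounds, is whether the same change reads alike with substituents on the phenyl sulfonyl group.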